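A few compounds are considered here, and "the series" means these few. Any claim that something is new, unique, unknown or untested is made for them only; others in the source may bear on it.

The measured compounds in an assay on isolated protein for inhibition of matrix metalloproteinase-9 (Homo sapiens); a higher number here means a weaker inhibitor, a lower number a stronger inhibitor:
compound 1, `O=C(OCc1ccccc1Br)c1cccc(=O)[nH]1`, which gives 59000 nM;
compound 2, `O=C(OCc1ccccc1)c1cccc(=O)[nH]1`, which gives 69000 nM;
compound 3, `Cc1ccc(COC(=O)c2cccc(=O)[nH]2)cc1`, which gives 68000 nM.

In this assay compound 2 gives the highest of the three numbers, yet its separation from compound 1 and from compound 3 lies within the scatter, so the three cannot be told apart on these data. Compound 4, `O=C(OCc1cccc(Cl)c1)c1cccc(=O)[nH]1`, differs from compound 2 in one place: chloro in place of hydrogen on an aromatic carbon.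

Going by the values given here, two measured steps bear on this change, each swapping a single substituent on the same ring of the shared core. The step of a 1.2-fold higher number from compound 1 to compound 2 (0.07 log units; within the scatter) and the step of a 1.0-fold lower number from compound 2 to compound 3 (0.01 log units; within the scatter) both lie within the scatter. A second halogen in place of hydrogen on that ring is therefore expected to do little; the estimated step is a 1.1-fold lower number from compound 2 to compound 4 (0.03 log units; within the scatter), no change beyond the scatter. Compound 4 is thus estimated at 65000 nM in this assay, with a likely range from 35000 nM to 120000 nM.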

Compound 4, half-maximal inhibitory concentration: 67000 nM
Beside the measured number, compound 4's estimate is 1.0-fold (0.01 log units) below it; the range from low to high includes it.
By their numbers in this assay, from the lowest: compounds 1, 4, 3 and 2 (each within the scatter of the next).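

In this assay the chloro group on an aromatic carbon, meta to a large group, gives a 1.0-fold lower number from compound 2 to compound 4 (0.01 log units; within the scatter) and so leaves the number within the scatter. The earlier steps shown here covered only bromo and methyl at other carbons of this six-membered aromatic ring, so compound 4 adds a third substituent at a further place, and all three steps on this ring stay within the scatter. Nothing available accounts for why this change has so small an effect.

On these data alone, whether a group of another kind at this position, such as an amine or a carboxylic acid, would move the number beyond the scatter remains open. Also open, as far as these compounds go, is whether a change elsewhere in the shared core, such as an amide in place of the ester, would do so.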